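The source may report more compounds than this note shows. Statements on the series, on what has been measured and on what is new or still open speak of the compounds shown alone.

In a functional assay on MKN-45 cells (Homo sapiens) for cytotoxicity, read by MTT assay, with a stated time of 72 h (a higher number here means a weaker inhibitor, a lower number a stronger inhibitor), the three measured compounds stand as follows:

Compound 1 `CN(C)CCn1cnnc1-c1cc(Oc2ccc(NC(=O)N/N=C/c3c[nH]c4ccccc34)cc2F)ccn1`: compound 1 gives 790 nM.
Compound 2 `CN(C)CCn1cnnc1-c1cc(Oc2ccc(NC(=O)N/N=C/c3ccc(O)c(Br)c3)cc2F)ccn1`: compound 2 gives 1860 nM.
Compound 3 `COc1cc(/C=N/NC(=O)Nc2ccc(Oc3ccnc(-c4nncn4CCN(C)C)c3)c(F)c2)cc(OC)c1OC`: compound 3 gives 2900 nM.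

Compound 1 has the lowest number of the three, and its steps to both other compounds lie beyond the scatter, so it is the strongest inhibitor in this set. Compound 2 and compound 3 lie within the scatter of each other, as a 1.6-fold higher number from compound 2 to compound 3 (0.19 log units; within the scatter) shows, so no order between them can be read.

Compound 4 `CN(C)CCn1cnnc1-c1cc(Oc2ccc(NC(=O)N/N=C/c3ccc(O)c(O)c3)cc2F)ccn1` has not yet been measured. It differs from compound 1 in one place: 3,4-dihydroxyphenyl in place of 1H-indol-3-yl on a carbon with a double bond to nitrogen. Among the compounds with values here, two measured steps bear on this change, since each of them also replaces the 1H-indol-3-yl on the carbon with a double bond to nitrogen by a substituted phenyl ring: a 2.4-fold higher number from compound 1 to compound 2 (0.37 log units; beyond the scatter) and a 3.7-fold higher number from compound 1 to compound 3 (0.56 log units; beyond the scatter). Both steps are modest and run in the same direction, towards a higher number. Compound 4 is therefore expected to follow them with a step of a 2.5-fold higher number from compound 1 to compound 4 (0.40 log units; beyond the scatter). For compound 4 the estimate in this assay is 2000 nM, with a range from 900 nM to 4500 nM.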

Compound 4, half-maximal inhibitory concentration: 3240 nM
Compound 4: middle estimate off by 1.6-fold (0.21 log units), on the low side; measured number inside the range.
By their numbers in this assay, from the lowest: compound 1; then compounds 2, 3 and 4 (each within the scatter of the next).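

In this assay, 3,4-dihydroxyphenyl on the carbon with a double bond to nitrogen also gives a weaker inhibitor than the 1H-indol-3-yl of compound 1 (a 4.1-fold higher number from compound 1 to compound 4 (0.61 log units; beyond the scatter)), so compound 1 now stays ahead of all three substituted phenyl rings shown. The new ring does not separate from the other two: both 3,4-dihydroxyphenyl in place of 3,4,5-trimethoxyphenyl (a 1.1-fold higher number from compound 3 to compound 4 (0.05 log units; within the scatter)) and hydroxy in place of bromo (a 1.7-fold higher number from compound 2 to compound 4 (0.24 log units; within the scatter)) stay within the scatter, so no order among these rings can be read. Nothing available accounts for the gap to compound 1.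

The compounds shown leave open how a plain phenyl ring would compare with these substituted rings. They also leave open whether a methyl group on the ring nitrogen of the 1H-indol-3-yl would keep the standing of compound 1.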